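The compounds below may be only part of what the source reports. "The series", "measured", "known", "first", "only" and "open" are said of these compounds alone.

Measured compounds:
Compound 1, `COc1ccc(C(C)NC(=O)/N=C(\N)NCCCc2sc(N)nc2C)cc1`, 38 nM
Compound 2, `Cc1nc(N)sc1CCCN/C(N)=N/C(=O)NC(c1ccccc1)C(C)C`, 34.7 nM
Compound 3, `Cc1nc(N)sc1CCCN/C(N)=N/C(=O)NC(C)c1ccccc1F`, 12.3 nM

Compound 3 gives the lowest number of the three in a functional assay on Right cardiac atrium for agonist activity at histamine H2 receptor (Cavia porcellus), with a stated time of 30 min, in the presence of a further agent that is not named here; a higher number here means that more compound is needed for the effect, a lower number that less compound is needed; its nearest neighbour is compound 2 and its furthest compound 1, both separated from it beyond the scatter. Compound 4, `Cc1ccc(C(C)NC(=O)/N=C(\N)NCCCc2sc(N)nc2C)cc1`, is not yet measured. It differs from compound 3 in one place: 4-methylphenyl in place of 2-fluorophenyl on a saturated chain carbon bound to an amide-type nitrogen and a saturated chain carbon.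

Going by the values given here, one measured step bears on this change. Replacing the 4-methoxyphenyl of compound 1 with the 2-fluorophenyl of compound 3 gave a 3.1-fold lower number from compound 1 to compound 3 (0.49 log units; beyond the scatter). Compound 4 carries a ring substituted in the same position as compound 1, so that step, read backwards, is the best guide; the step from compound 2 to compound 3 is not a single change and is not used. Compound 4 is therefore expected to show a 2.4-fold higher number from compound 3 to compound 4 (0.39 log units; beyond the scatter), a rise of the number. Compound 4 is estimated at 30 nM in this assay, with a range from 12 nM to 75 nM.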

Compound 4, half-maximal effective concentration: 22.4 nM
Estimate against measurement, compound 4: 1.3-fold (0.13 log units) above; the measured number falls inside the stated range.
By their numbers in this assay, from the lowest: compounds 3, 4, 2 and 1 (each within the scatter of the next, the first and the last beyond it).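

In this assay the change from 2-fluorophenyl to 4-methylphenyl on the saturated chain carbon gives a 1.8-fold higher number from compound 3 to compound 4 (0.26 log units; within the scatter), so this position accepts the swap without a separation that can be read. Methyl in place of methoxy on an aromatic carbon gives a 1.7-fold lower number from compound 1 to compound 4 (0.23 log units; within the scatter), which also cannot be read as a separation. Compound 4 therefore stands within the scatter of both compound 1 and compound 3, although the earlier step alone, a 3.1-fold lower number from compound 1 to compound 3 (0.49 log units; beyond the scatter), had set those two apart.

Going by these compounds, whether an amine or a carboxylic acid in place of the methyl of compound 4 would stay within that same scatter remains open. The compounds shown give only these numbers. Nothing else measured here speaks to them.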